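Replacing the 5-chloropyrazin-2-yl group of compound 3

A few compounds are considered here, and "the series" means these few. Any claim that something is new, unique, unknown or untested is made for them only; others in the source may bear on it.

In a physicochemical assay for solubility, read by spectrophotometry (on this read-out lower numbers stand for lower solubility and higher numbers for higher solubility), compound 1 (`O=C(Oc1ccc(Cl)cc1C(=O)Nc1ccc(Cl)c(Cl)c1)c1cnc(Cl)cn1`) gives < 100000 nM as a limit, not a number. Compound 2 (`O=C(Oc1ccc(Br)cc1C(=O)Nc1ccc(C(F)(F)F)cc1)c1cnc(Cl)cn1`) gives < 100000 nM as a limit too. Compound 3 (`O=C(Oc1ccc(Br)cc1C(=O)Nc1ccc(Cl)c(Cl)c1)c1cnc(Cl)cn1`) gives < 100000 nM as a limit as well. All three therefore stand together (the limit of < 100000 nM in this assay, at which 3 of the 3 values shown sit). Compound 4 (`O=C(NCCCCl)Oc1ccc(Br)cc1C(=O)Nc1ccc(Cl)c(Cl)c1`) carries (3-chloropropyl)amino in place of 5-chloropyrazin-2-yl on a carbonyl carbon. Two measured steps reach compound 3 (a step that the two limits leave unreadable from compound 1 to compound 3) and (a step that the two limits leave unreadable from compound 2 to compound 3), but neither changes this group and neither has a readable size. They offer no firm size or direction, so the expected change remains only a rough estimate (a step that the limit leaves unreadable from compound 3 to compound 4). Compound 4 is expected near 40000 nM within an estimated range (5000 nM to 100000 nM) and may well report only a limit again.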

Compound 4, solubility: < 50000 nM
Compound 4 ended at the assay's limit (the forecaster's own chance of this, stated with the estimate: 75%); the middle value is on the limit's open side.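

In this assay compound 3 gives < 100000 nM as a limit, not a number. Compound 4 gives < 50000 nM as a limit too, so the change from compound 3 to compound 4 cannot be read. The compounds shown leave open whether (3-chloropropyl)amino in place of 5-chloropyrazin-2-yl changes the read-out at all, and in which direction.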